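Urea head-group swap toward a ketopyrrolidine amide

A few compounds are considered here, and "the series" means these few. Any claim that something is new, unique, unknown or untested is made for them only; others in the source may bear on it.

Compound 2 `Cc1cc(C(=O)N2CCCCc3ccccc32)ccc1CNC(=O)NCC(=O)N1CCCCC1` gives 150 nM in a functional assay on HEK293 cells for agonist activity at Vasopressin V2 receptor (Homo sapiens), read by a luciferase reporter and cAMP accumulation (on this read-out higher numbers stand for an effect only at larger amounts of compound and lower numbers for an effect already at smaller amounts), the highest of the three numbers shown. Compound 1 `Cc1cc(C(=O)N2CCCCc3ccccc32)ccc1CNC(=O)NCC(=O)N1CCCC1` gives 100 nM, and the step of a 1.5-fold higher number from compound 1 to compound 2 (0.18 log units; within the scatter) is within the scatter. Compound 3 `Cc1cc(C(=O)N2CCCCc3ccccc32)ccc1CNC(=O)N1C[C@H](OC(C)(C)C)C[C@H]1C(=O)N(C)C` gives 46 nM, a number beyond the scatter below that of compound 2. Compound 4 `Cc1cc(C(=O)N2CCCCc3ccccc32)ccc1CNC(=O)N1CC(=O)C[C@H]1C(=O)N(C)C` differs from compound 2 by 2-(dimethylcarbamoyl)-4-oxopyrrolidin-1-yl in place of (((piperidin-1-yl)carbonyl)methyl)amino on a carbonyl carbon. For the measured compounds named here, no measured step covers this change directly; the nearest pointer is compound 3, whose value 46 nM sits at the lower end of the set with a related pyrrolidinyl group. On that basis compound 4 is expected to fall near compound 3, a step of a 2.5-fold lower number from compound 2 to compound 4 (0.40 log units; beyond the scatter) toward lower numbers. The estimate for compound 4 is 60 nM, in the range 25 nM to 150 nM.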

Compound 4, half-maximal effective concentration: 27 nM
Beside the measured number, compound 4's estimate is 2.2-fold (0.35 log units) above it; low and high end bracket the measured number.
By their numbers in this assay, from the lowest: compounds 4 and 3 (each within the scatter of the next); then compounds 1 and 2 (each within the scatter of the next).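

In this assay, for the compounds shown here, 2-(dimethylcarbamoyl)-4-oxopyrrolidin-1-yl on this carbonyl carbon gives a 5.6-fold lower number from compound 2 to compound 4 (0.74 log units; beyond the scatter) and a 3.7-fold lower number from compound 1 to compound 4 (0.57 log units; beyond the scatter), so this is the first change here with steps beyond the scatter, whereas swapping the piperidin-1-yl and pyrrolidin-1-yl groups stayed within it. The entering group has no hydrogen-bond donor, so a donor at this place is not needed for the lower number. Nothing measured explains the shift. Still open, from the compounds shown here alone, is how a hydroxyl or an amine in place of the ketone would read, and how a carboxylic acid would compare with the dimethylcarbamoyl group.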